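Compound 3 to compound 4: replacing the 3-hydroxypyrrolidin-1-yl group

The compounds below may be only part of what the source reports. "The series", "measured", "known", "first", "only" and "open" are said of these compounds alone.

In a physicochemical assay for solubility, read by HPLC, using the shake flask method, in phosphate buffer, with a stated time of 2 h, at pH 6.5 (on this read-out higher numbers stand for higher solubility and lower numbers for lower solubility), compound 1 (`Nc1ncc(-c2ccc(C(=O)N3CCC(N)CC3)cc2)nc1-c1ccc(C(F)(F)F)cc1`) gives 88000 nM and compound 2 (`Nc1ncc(-c2ccc(C(=O)N3CCC(O)C3)cc2)nc1-c1ccc(C(F)(F)F)cc1`) gives 77000 nM, while compound 3 (`Nc1ncc(-c2ccc(C(=O)N3CC[C@@H](O)C3)cc2)nc1-c1ccc(C(F)(F)F)cc1`) gives 90000 nM. Compound 3 therefore stands level with the other two, as a 1.0-fold higher number from compound 1 to compound 3 (0.01 log units; within the scatter) and a 1.2-fold higher number from compound 2 to compound 3 (0.07 log units; within the scatter) both lie within the scatter.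

Compound 4 (`COC(=O)c1ccc(-c2cnc(N)c(-c3ccc(C(F)(F)F)cc3)n2)cc1`) follows from compound 3 through one change: methoxy in place of 3-hydroxypyrrolidin-1-yl on a carbonyl carbon (in words, methoxy in place of 3-hydroxypyrrolidin-1-yl on a carbonyl carbon).

The measured steps bear on this only loosely. Both a 1.1-fold lower number from compound 1 to compound 2 (0.06 log units; within the scatter) and a 1.0-fold higher number from compound 1 to compound 3 (0.01 log units; within the scatter) exchange 4-aminopiperidin-1-yl for 3-hydroxypyrrolidin-1-yl on that carbonyl carbon, and both stay within the scatter. Within the data shown here, in all three measured compounds a ring stays on the carbonyl carbon, whereas methoxy enters with no ring, so no measured step gauges this replacement directly. The flat steps cannot simply be carried over, and the size of the change remains a judgement. Starting from compound 3 at 90000 nM, a clear fall is expected rather than a step within the scatter. The estimated step is a 15-fold lower number from compound 3 to compound 4 (1.18 log units; beyond the scatter) in this assay, with wide uncertainty. The expected value for compound 4 is 6000 nM (estimated range 1200 nM to 30000 nM).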

Compound 4, solubility: < 5000 nM
Compound 4: no number, only a limit; the forecaster's own chance of this, stated with the estimate: 15%; middle value at least 1.2-fold (0.07 log units) from the limit.
By their numbers in this assay, from the lowest: compounds 2, 1 and 3 (each within the scatter of the next). At a limit, below all of these: compound 4.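

In this assay compound 4 gives < 5000 nM, which is a limit and not a number. Even so, the steps to it can be read, and all three are large and beyond the scatter: an at least 18-fold lower number from compound 3 to compound 4 (1.25 log units; beyond the scatter), an at least 15-fold lower number from compound 2 to compound 4 (1.18 log units; beyond the scatter) and an at least 17-fold lower number from compound 1 to compound 4 (1.24 log units; beyond the scatter). Compounds 1, 2 and 3 all keep a ring attached through its nitrogen to the carbonyl carbon, and among them neither the change of ring nor the drawn configuration moved the number beyond the scatter, so the flat picture they gave does not extend to methoxy, and this position is shown for the first time to matter in this assay.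

As far as these compounds go, the true size of these steps stays open, because only a limit stands for compound 4: the limit of < 5000 nM in this assay, at which 1 of the 4 values shown sits. Also open, from the compounds shown here alone, is whether the ring or the nitrogen on the carbonyl carbon carries the difference, a question that an open-chain amine such as dimethylamino on that carbonyl carbon, or a carboxylic acid in place of the methoxycarbonyl, would help to separate.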